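The source may report more compounds than this note shows. Statements on the series, on what has been measured and on what is new or still open speak of the compounds shown alone.

Measured so far:
Compound 1 `Cc1nc2c(Br)c(Br)c(Br)c(Br)c2n1CCCC#N` gives 68% in a functional assay on CCRF-CEM cells (Homo sapiens) for cytotoxicity, read by MTT assay, with a stated time of 24 h, tested at 10 uM; on this read-out higher numbers stand for a weaker effect at the one concentration tested and lower numbers for a stronger effect.
Compound 2 `Cc1nc2c(Br)c(Br)c(Br)c(Br)c2n1CCC#N` gives 84% in this assay.
Compound 3 `N#CCCn1cnc2c(Br)c(Br)c(Br)c(Br)c21` gives 80% in this assay.

Compound 3 stands with compound 2 in this assay: its number and the number of compound 2 lie within the scatter of each other, while the number of compound 1 lies beyond the scatter, lower than that of compound 3. The step of a number 4 percentage points lower from compound 2 to compound 3 (within the scatter) is small; the step of a number 16 percentage points higher from compound 1 to compound 2 (beyond the scatter) is the only one in the set that goes beyond the scatter.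

Compound 4 `N#CCCCn1cnc2c(Br)c(Br)c(Br)c(Br)c21` is not yet measured. The change from compound 3 to compound 4 is cyanomethyl in place of cyano on a saturated chain carbon, two bonds along the chain from an aromatic nitrogen. The step from compound 1 to compound 2 is the same change run in the opposite direction, on the core that carries the methyl, and it gave a number 16 percentage points higher from compound 1 to compound 2 (beyond the scatter). Going by the values given here, that step is the only measured guide, so a step of similar size and of the opposite sign is expected here, a lower number in this assay: a number 15 percentage points lower from compound 3 to compound 4 (beyond the scatter). Whether the methyl on the core alters the size of such a step cannot be told from the compounds at hand. Compound 4 is therefore estimated at 65%, in the range 52% to 78%.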

Compound 4, a percentage reported as activity, at one concentration (the size of the read-out at that concentration, not a potency): 85%
Compound 4: the middle estimate sits 20 percentage points below what was measured; the measured number lies above the stated range.
By their numbers in this assay, from the lowest: compound 1; then compounds 3, 2 and 4 (each within the scatter of the next).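

In this assay, cyanomethyl in place of cyano on a saturated chain carbon, two bonds along the chain from an aromatic nitrogen, gives a number 5 percentage points higher from compound 3 to compound 4 (within the scatter), so the change that moved the number on the core of compound 1 does not do so on the core of compound 3: the same change on two cores in this assay, a number 16 percentage points higher (beyond the scatter) from compound 1 to compound 2 and a number 5 percentage points lower (within the scatter) from compound 4 to compound 3, 21 percentage points apart, beyond the scatter of two such steps

Hydrogen in place of methyl on an aromatic carbon depends on the chain in the same way, giving a number 17 percentage points higher from compound 1 to compound 4 (beyond the scatter) with the 3-cyanopropyl chain, a step that the 2-cyanoethyl chain does not match: the same change on two cores in this assay, a number 4 percentage points lower (within the scatter) from compound 2 to compound 3 and a number 17 percentage points higher (beyond the scatter) from compound 1 to compound 4, 21 percentage points apart, beyond the scatter of two such steps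

Among these compounds, the lower number of compound 1 appears only where methyl and the 3-cyanopropyl chain occur together.

Going by these compounds, whether this pairing persists with a longer chain, or with a carboxylic acid or an amine in place of the nitrile, stays open. On these data alone, what ethyl in place of the methyl would do with these chains also stays open.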